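The source may hold more compounds than are shown below. What is called first, only, known or untested is meant among the compounds shown, and "the series" means these compounds.

Measured compounds:
compound 1, `COc1cc(/C=C2\CN(C)C/C(=C\c3cccnc3)C2=O)cc(OC)c1OC`, 9520 nM
compound 2, `COc1ccc(/C=C2\CN(C)C/C(=C\c3cccnc3)C2=O)c(OC)c1OC`, 5160 nM
compound 3, `COc1cc(/C=C2\CN(C)C/C(=C\c3ccncc3)C2=O)cc(OC)c1OC`, 9800 nM

All three numbers come from a functional assay on HepG2 cells (Homo sapiens) for cytotoxicity, read by MTT assay, with a stated time of 24 h; a higher number here means a weaker inhibitor, a lower number a stronger inhibitor. The three compounds share a core and differ in the groups hanging off it. Compound 1 and compound 3 share one core; the difference between the core of compound 1 and the core of compound 2 is not broken down here. Compound 3 differs from compound 1 by one change, (pyridin-4-yl in place of pyridin-3-yl on a double-bonded chain carbon bound to a double-bonded ring carbon). That change made the step of a 1.0-fold higher number from compound 1 to compound 3 (0.01 log units; within the scatter), so here the two forms of the pyridine ring gave the same result within the usual scatter of this assay. The values of compound 1, compound 2 and compound 3 all lie within that scatter of one another, so no order among them can be read from these numbers.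

Compound 4, `COc1ccc(/C=C2\CN(C)C/C(=C\c3ccncc3)C2=O)c(OC)c1OC`, has not been measured. Among the compounds with values here, it differs from compound 2 by pyridin-4-yl in place of pyridin-3-yl on a double-bonded chain carbon bound to a double-bonded ring carbon, which is the same change as the one from compound 1 to compound 3. Within the data shown here, the expectation is that the step from compound 2 to compound 4 is about as small as the one already seen, a 1.0-fold higher number from compound 2 to compound 4 (0.01 log units; within the scatter), because the only measured example of this change is a 1.0-fold higher number from compound 1 to compound 3 (0.01 log units; within the scatter). Compound 4 is therefore expected to give about 5300 nM in this assay, estimated to lie between 2600 nM and 10600 nM.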

Compound 4, half-maximal inhibitory concentration: 3560 nM
Beside the measured number, compound 4's estimate is 1.5-fold (0.17 log units) above it; the measured number falls inside the stated range.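

In this assay, putting pyridin-4-yl in place of pyridin-3-yl on the second core gave a 1.4-fold lower number from compound 2 to compound 4 (0.16 log units; within the scatter) and so stayed as small as the usual scatter allows. Set side by side, the two examples of this change do not differ: the same change on two cores in this assay, a 1.0-fold higher number (0.01 log units; within the scatter) from compound 1 to compound 3 and a 1.4-fold lower number (0.16 log units; within the scatter) from compound 2 to compound 4, 1.5-fold (0.17 log units) apart, within the scatter of two such steps. This shows that, on these two cores, the swap between the two pyridine forms had no effect that this assay can resolve, but it does not prove that the two forms are equal, and two cores are too few to predict the same small step on any other core in the series.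

The compounds shown leave open what a plain phenyl, a pyridin-2-yl, or a ring carrying an amine or a carboxylic acid would give on a double-bonded chain carbon bound to a double-bonded ring carbon, since the two pyridine forms are the only groups compared there. They also leave open whether a longer chain in place of the methyl on the ring nitrogen would change the result, and whether the pyridine swap would stay this small on a core with other groups.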